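A few compounds are considered here, and "the series" means these few. Any claim that something is new, unique, unknown or untested is made for them only; others in the source may bear on it.

Series values in a functional assay on DU-145 cells (Homo sapiens) for cytotoxicity; on this read-out lower numbers stand for stronger inhibition of growth and higher numbers for weaker inhibition of growth:

- compound 1 `CSc1ccc(C2=C(c3ccc(C)c(C)c3)C(=O)N3CCCC3C2)cc1` gives 500 nM
- compound 2 `CSc1ccc(C2=C(c3ccc(F)c(C)c3)C(=O)N3CCCC3C2)cc1` gives 500 nM
- compound 3 `CSc1ccc(C2=C(c3ccc(OCC4CO4)cc3)C(=O)N3CCCC3C2)cc1` gives 500 nM

Compound 3 stands level with compound 1 and compound 2 on these numbers, so the three measured compounds do not separate in this assay. The open question is compound 4 `CSc1ccc(C2=C(c3ccc(SC)cc3)C(=O)N3CCCC3C2)cc1`, which carries methylsulfanyl in place of (oxiran-2-yl)methoxy on an aromatic carbon of a six-membered aromatic ring of carbon only, para to a large group: methylsulfanyl in place of (oxiran-2-yl)methoxy on an aromatic carbon.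

For the measured compounds named here, no measured pair tests this exchange directly. Going by the values given here, the only measured step between compounds that differ in one place is no change at the digits printed from compound 1 to compound 2 (within the scatter), for fluoro in place of methyl on an aromatic carbon. That step involves different groups, so it offers only indirect support. Compound 3, with its (oxiran-2-yl)methoxy group, still gives 500 nM, the same number as compound 1 and compound 2.

On this limited evidence, no step beyond the scatter is expected in this assay, and neither direction is favoured. The estimated step is no change at the digits printed from compound 3 to compound 4 (within the scatter). Compound 4 is estimated at 500 nM, with an expected range from 180 nM to 1400 nM.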

Compound 4, concentration for 50% growth inhibition: 8000 nM
For compound 4 the middle estimate is 16-fold (1.20 log units) below the measured one; measured number above the stated range.
By their numbers in this assay, from the lowest: compounds 1, 2 and 3 (each within the scatter of the next); then compound 4.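

In this assay, for the compounds shown here, methylsulfanyl in place of (oxiran-2-yl)methoxy on an aromatic carbon, para to a large group, gives a 16-fold higher number from compound 3 to compound 4 (1.20 log units; beyond the scatter) and is the first change to exceed the scatter. The same separation appears when the whole aryl group is exchanged: 4-(methylsulfanyl)phenyl in place of 3,4-dimethylphenyl gives a 16-fold higher number from compound 1 to compound 4 (1.20 log units; beyond the scatter), and 4-(methylsulfanyl)phenyl in place of 4-fluoro-3-methylphenyl gives a 16-fold higher number from compound 2 to compound 4 (1.20 log units; beyond the scatter), so the level numbers of compounds 1, 2 and 3 do not extend to every group on this ring. Nothing on hand accounts for the weaker inhibition of growth seen with compound 4.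

The compounds shown leave open whether the higher number belongs specifically to methylsulfanyl or would also follow from other exchanges of (oxiran-2-yl)methoxy at this carbon. A methoxy group, an amine or a carboxylic acid in that place would show whether compound 3 or compound 4 is the better guide to the substituents at this position.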